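Removing the Nitro Group from a Sulfonamide Series

The compounds below may be only part of what the source reports. "The series", "measured", "known", "first", "only" and "open" are said of these compounds alone.

Compound 1 `CC(=O)c1ccc(NC(=O)C(CC(C)C)N(C(=O)c2ccccc2)S(=O)(=O)c2ccc([N+](=O)[O-])cc2)cc1` and compound 3 `CC(=O)c1ccc(NC(=O)C(CC(C)C)N(C(=O)c2ccccc2)S(=O)(=O)c2ccccc2)cc1` share one core and differ in a single group. In a functional assay for inhibition, read by spectrophotometry, with a stated time of 20 min, tested at 5 mg/mL (on this read-out higher numbers stand for a stronger effect at the one concentration tested and lower numbers for a weaker effect), compound 1 gives 81.3%, while compound 3 gives 52.2%. The change between them is hydrogen in place of nitro on an aromatic carbon, and the step it made is a number 29.1 percentage points lower from compound 1 to compound 3 (beyond the scatter).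

Compound 2 `CC(=O)c1ccc(NC(=O)C2CC(O)CN2S(=O)(=O)c2ccc([N+](=O)[O-])cc2)cc1` rests on a different core; the difference between the two cores is not broken down here. In this assay compound 2 gives 70.7%, a number that stands between those of compound 1 and compound 3.

Compound 4 `CC(=O)c1ccc(NC(=O)C2CC(O)CN2S(=O)(=O)c2ccccc2)cc1` has not yet been measured. Relative to compound 2 the change is hydrogen in place of nitro on an aromatic carbon, the same change seen from compound 1 to compound 3, at the same place. Going by the values given here, a drop of comparable size is expected for compound 4 because the one earlier example gave a number 29.1 percentage points lower from compound 1 to compound 3 (beyond the scatter), though a single precedent on another core is only a rough guide. The step that this estimate means for compound 4 is expected to be a number 25.7 percentage points lower from compound 2 to compound 4 (beyond the scatter). For compound 4 the estimate in this assay is 45%, with a range from 25% to 65%.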

Compound 4, a percentage reported as inhibition, at one concentration (the size of the read-out at that concentration, not a potency): 58.7%
For compound 4 the middle estimate is 13.7 percentage points below the measured one; measured number inside the range.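

On the core of compound 2, in this assay, hydrogen in place of nitro gives a number 12 percentage points lower from compound 2 to compound 4 (beyond the scatter), so the change lowers the number on both cores shown and its direction carries over. Going by these compounds alone, its size does not carry over, as the two steps differ by more than repeated measurements would explain: the same change on two cores in this assay, a number 29.1 percentage points lower (beyond the scatter) from compound 1 to compound 3 and a number 12 percentage points lower (beyond the scatter) from compound 2 to compound 4, 17.1 percentage points apart, beyond the scatter of two such steps With only two pairs, this shows that the effect of going from 4-nitrophenyl to phenyl depends on the core, but it does not show which feature of the cores is responsible or what size of step a further core would give.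

The compounds shown leave open how other groups in the place of the nitro group, such as an amine, a nitrile or a carboxylic acid, would read in this assay. They also leave open which part of the difference between the two cores goes with the larger step.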